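Chain methyl removed from the shared core of compound 3

A few compounds are considered here, and "the series" means these few. Any claim that something is new, unique, unknown or untested is made for them only; others in the source may bear on it.

Compound 1 `CC(CNC1CCCC1)Oc1cccc2ccc(N)nc12` gives 30 nM in a functional assay on IMR-32 cells with melanin-concentrating hormone receptor 1 (Homo sapiens) as the target, read by fluorescence; a higher number here means a weaker inhibitor, a lower number a stronger inhibitor.
Compound 2 `CC(CNCc1ccccc1)Oc1cccc2ccc(N)nc12` gives 340 nM.
Compound 3 `CC(CNCc1ccoc1)Oc1cccc2ccc(N)nc12` gives 100 nM.

Compound 3 stands second highest of the three numbers in this assay: a 3.3-fold higher number from compound 1 to compound 3 (0.52 log units; beyond the scatter), and a 3.4-fold lower number from compound 2 to compound 3 (0.53 log units; beyond the scatter). The three measured steps all alter the group on the amine nitrogen, the largest being an 11-fold higher number from compound 1 to compound 2 (1.05 log units; beyond the scatter).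

Compound 4 `Nc1ccc2cccc(OCCNCc3ccoc3)c2n1` differs from compound 3 by hydrogen in place of methyl on a saturated chain carbon bound to an oxygen on an aromatic ring and a saturated chain carbon. Within the data shown here, no measured step touches this place, so the measured steps offer no direct guide; the chain itself is otherwise unchanged. With nothing pointing either way, a step within the scatter is expected, no change at the digits printed from compound 3 to compound 4 (within the scatter). Compound 4 is therefore estimated at 100 nM in this assay, with a range from 40 nM to 250 nM.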

Compound 4, half-maximal inhibitory concentration: > 10000 nM
Compound 4: a limit, no number; the forecaster's own chance of this, stated with the estimate: 2%; middle value at least 100-fold (2.00 log units) from the limit.
By their numbers in this assay, from the lowest: compound 1; then compound 3; then compound 2. At a limit, above all of these: compound 4.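

In this assay hydrogen in place of methyl on the saturated chain carbon bound to an oxygen on an aromatic ring gives an at least 100-fold higher number from compound 3 to compound 4 (2.00 log units; beyond the scatter) and so outweighs every step seen on the amine nitrogen. Compound 4 stands at a limit and not at a number: the limit of > 10000 nM in this assay, at which 1 of the 4 values shown sits. This place, where only one heavy atom leaves, therefore separates a measured number from a limit, which no change on the amine nitrogen has done.

As far as these compounds go, whether an ethyl group or a longer chain here would keep a measurable number remains open. So does whether losing the methyl has the same result with cyclopentyl on the amine nitrogen.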